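Amide nitrogen substituent change in the LoVo series

The source may report more compounds than this note shows. Statements on the series, on what has been measured and on what is new or still open speak of the compounds shown alone.

Measured compounds:
compound 1 `Cc1noc(C)c1-c1cnc(N)c(Oc2ccc(C(=O)Nc3ccccc3)cc2)n1` — 5740 nM
compound 2 `Cc1noc(C)c1-c1cnc(N)c(Oc2ccc(C(=O)Nc3cccc(Cl)n3)cc2)n1` — 39300 nM
compound 3 `Cn1cc(-c2cnc(N)c(Oc3ccc(C(=O)Nc4ccccc4)cc3)n2)cn1` — 9210 nM

In a functional assay on LoVo cells (Homo sapiens) for inhibition, read by MTT assay, with a stated time of 72 h (a lower number here means a stronger inhibitor, a higher number a weaker inhibitor), compound 3 gives 9210 nM, the second highest of the three numbers; compound 1 sits within the scatter of it (a 1.6-fold higher number from compound 1 to compound 3 (0.21 log units; within the scatter)), while compound 2 lies beyond it.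

Compound 4 `Cn1cc(-c2cnc(N)c(Oc3ccc(C(=O)Nc4cc(Cl)ccn4)cc3)n2)cn1` differs from compound 3 in one place: 4-chloropyridin-2-yl in place of phenyl on an amide-type nitrogen. For the measured compounds named here, no measured pair carries exactly this change. Going by the values given here, the closest precedent is a 6.8-fold higher number from compound 1 to compound 2 (0.84 log units; beyond the scatter), where a 6-chloropyridin-2-yl replaced phenyl on the same kind of nitrogen and the number rose well beyond the scatter. The chlorine sits elsewhere on the ring here, so the size may differ, but a rise of similar order in this assay is expected.

For compound 4 the estimated value is 40000 nM, range 12000 nM to 130000 nM, which is expected to correspond to a 4.3-fold higher number from compound 3 to compound 4 (0.64 log units; beyond the scatter).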

Compound 4, half-maximal inhibitory concentration: 26600 nM
Compound 4: middle estimate off by 1.5-fold (0.18 log units), on the high side, within the range that was stated.
By their numbers in this assay, from the lowest: compounds 1 and 3 (each within the scatter of the next); then compounds 4 and 2 (each within the scatter of the next).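

In this assay, the step (a 2.9-fold higher number from compound 3 to compound 4 (0.46 log units; beyond the scatter)) shows that a rise beyond the scatter on replacing phenyl at the amide-type nitrogen with a chloropyridin-2-yl group also occurs in a compound carrying 1-methyl-1H-pyrazol-4-yl. It therefore no longer rests only on the 3,5-dimethyl-1,2-oxazol-4-yl pair (a 6.8-fold higher number from compound 1 to compound 2 (0.84 log units; beyond the scatter)). The two steps differ in chlorine placement as well as in that group, so neither difference can be read alone.

Still open, from the compounds shown here alone, is whether the rise follows the ring nitrogen or the chlorine, which an unsubstituted pyridin-2-yl or a chlorophenyl group at this nitrogen would separate. No supporting data explain the rise.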